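This account rests on a few compounds, and the source may have more. Where it says the series, first, only, none or still open, it means among the compounds named here.

Working notes on the series in an ADME assay on L6 cells (Rattus norvegicus) for cytotoxicity, read by resazurin assay, with a stated time of 72 h; a lower number here means a stronger inhibitor, a higher number a weaker inhibitor.

Two compounds of the series carry a number. Compound 1 `N/C(CC(O)c1cccc2ccccc12)=N\N=C\c1ccc(Cl)c(Cl)c1` gives 16000 nM in this assay, and compound 2 `N/C(CC(O)c1cccc2ccccc12)=N\N=C\c1ccccc1` gives 17000 nM. Within the data shown here, the one step between them, a 1.1-fold higher number from compound 1 to compound 2 (0.03 log units; within the scatter), shows that swapping one aromatic group for another on the carbon with a double bond to nitrogen left the read-out essentially unchanged.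

Compound 3 `N/C(CC(O)c1ccc2ccccc2c1)=N\N=C\c1ccco1` stands nowhere on the numbers shown: in this assay compound 3 is recorded as "not determined" (no result reported), so there is no value from which to count a step to its neighbour.

Compound 4 `Cc1ccc(/C=N/N=C(\N)CC(O)c2ccc3ccccc3c2)cc1` differs from compound 3 in one place: 4-methylphenyl in place of furan-2-yl on a carbon with a double bond to nitrogen. Among the measured compounds shown here, the only measured step that bears on this change is the one from compound 1 to compound 2, which also replaced an aromatic group at the same position and stayed within the scatter. On that basis no step beyond the scatter is expected for the change from compound 3 to compound 4 in this assay, although compound 3 itself offers no number to anchor it.

Compound 4 is therefore estimated to give 17000 nM in this assay, with an expected range from 8000 nM to 40000 nM.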

Compound 4, half-maximal inhibitory concentration: 103000 nM
The estimate for compound 4 lay 6.1-fold (0.78 log units) below the measured number; the whole stated range lies below it.
By their numbers in this assay, from the lowest: compounds 1 and 2 (each within the scatter of the next); then compound 4.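

In this assay, among these compounds, compound 3 has no number, so no step to compound 4 can be read. The compounds shown leave open whether 4-methylphenyl in place of furan-2-yl on a carbon with a double bond to nitrogen shifts the read-out at all. No supporting measurement is available to explain the result for compound 4.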